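The compounds below may be only part of what the source reports. "The series", "measured", "known", "first", "only" and "open" are said of these compounds alone.

The measured compounds and their values:
- compound 1, `C#CCOc1ccc(-c2noc(N(CC#C)C3CCCCC3)n2)cc1`, gives > 200 ug/mL in an ADME assay on HepG2 cells (Homo sapiens) for cytotoxicity, read by MTT assay, with a stated time of 48 h; a higher number here means that more compound is tolerated, a lower number that less compound is tolerated
- compound 2, `C#CCN(c1nc(-c2ccc(OC)cc2)no1)C1CCCCC1`, gives 72.5 ug/mL
- compound 3, `CC(=O)OC[C@H]1O[C@H](OC[C@@H](Cn2cc(CN(c3nc(-c4ccc(Br)cc4)no3)C3CCCCC3)nn2)OC(C)=O)C=C[C@@H]1OC(C)=O`, gives 47.6 ug/mL

The value of compound 1 is a limit of the assay and not a number (the limit of > 200 ug/mL in this assay, at which 1 of the 3 values shown sits). Of the two numbers shown, compound 2 gives one and compound 3 the other, and the two lie within the scatter of each other, so neither can be placed above the other. Going by the values given here, the single measured step, an at least 2.7-fold lower number from compound 1 to compound 2 (0.44 log units; beyond the scatter), concerns hydrogen in place of ethynyl on a saturated chain carbon bound to an oxygen on an aromatic ring, and so does not touch the change now in question. Compound 4, `C#CCN(c1nc(-c2ccc([N+](=O)[O-])cc2)no1)C1CCCCC1`, differs from compound 2 by nitro in place of methoxy on an aromatic carbon. Among the compounds with values here, no measured pair shows an exchange of this kind on the six-membered aromatic ring of carbon only, so no step beyond the scatter is expected in this assay in either direction. Compound 4 is therefore estimated at 60 ug/mL, between 30 ug/mL and 150 ug/mL. The step this estimate implies, a 1.2-fold lower number from compound 2 to compound 4 (0.08 log units; within the scatter), is expected to stay within the scatter.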

Compound 4, half-maximal cytotoxic concentration: 43.7 ug/mL
For compound 4 the middle estimate is 1.4-fold (0.14 log units) above the measured one; the range from low to high includes it.
By their numbers in this assay, from the lowest: compounds 4, 3 and 2 (each within the scatter of the next). At a limit, above all of these: compound 1.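

Nitro in place of methoxy on this aromatic carbon, para to a large group, gives a 1.7-fold lower number from compound 2 to compound 4 (0.22 log units; within the scatter) in this assay, so two very different groups at this place cannot be told apart. Nitro in place of propargyloxy on the same carbon gives an at least 4.5-fold lower number from compound 1 to compound 4 (0.66 log units; beyond the scatter), which sets propargyloxy apart from nitro as the earlier step had set it apart from methoxy. The value of compound 1 is a limit of the assay and not a number, which leaves the full size of both steps unknown: the limit of > 200 ug/mL in this assay, at which 1 of the 4 values shown sits.

On these data alone, whether an amine or a carboxylic acid at this place would group with methoxy and nitro or with propargyloxy stays open. Also open, as far as these compounds go, is whether a longer chain without the ethynyl, such as propoxy, would group with propargyloxy.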